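The source may hold more compounds than are shown below. What is called first, only, known or untested is meant among the compounds shown, and "the series" means these compounds.

Three analogues of a shared core were examined in a physicochemical assay for solubility, with a stated time of 18 h, at pH 7.4; on this read-out higher numbers stand for higher solubility and lower numbers for lower solubility. Compound 1 `COc1cccc(CNCCCNc2ccnc3cc(Oc4cccc(N(C)C)c4)ccc23)c1O` gives 14500 nM in this assay. Compound 2 `COc1cccc(CNCCCNc2ccnc3cc(-c4ccc(F)cc4)ccc23)c1O` gives 32000 nM, and compound 3 `COc1cccc(CNCCCNc2ccnc3cc(Cc4cccc(C(F)(F)F)c4)ccc23)c1O` gives 4200 nM. Among these three numbers compound 3 stands lowest: the change is a 3.5-fold lower number from compound 1 to compound 3 (0.54 log units; beyond the scatter), and a 7.6-fold lower number from compound 2 to compound 3 (0.88 log units; beyond the scatter), while a 2.2-fold higher number from compound 1 to compound 2 (0.34 log units; beyond the scatter).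

Compound 4 `COc1cccc(CNCCCNc2ccnc3cc(Cc4ccc(F)cc4Cl)ccc23)c1O` differs from compound 3 in one place: 2-chloro-4-fluorophenyl in place of 3-(trifluoromethyl)phenyl on a saturated chain carbon bound to an aromatic carbon. Within the data shown here, none of the measured steps bears directly on this exchange of one substituted phenyl for another on the saturated chain carbon; each measured step instead replaces the entire group attached to the aromatic carbon of the core, as in the step from compound 1 to compound 3 and the step from compound 2 to compound 3. Among the measured compounds shown here, with no comparable step available, a change in this assay beyond the scatter is not expected for compound 4, so the step from compound 3 to compound 4 is estimated at a 1.2-fold higher number from compound 3 to compound 4 (0.08 log units; within the scatter). Compound 4 is therefore expected to give about 5000 nM in this assay, within a range of 2000 nM to 14000 nM.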

Compound 4, solubility: 4200 nM
Compound 4: the middle estimate sits 1.2-fold (0.08 log units) above what was measured; measured number inside the range.
By their numbers in this assay, from the lowest: compounds 3 and 4 (each within the scatter of the next); then compound 1; then compound 2.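

In this assay, among these compounds, putting 2-chloro-4-fluorophenyl in place of 3-(trifluoromethyl)phenyl on a saturated chain carbon bound to an aromatic carbon gives no change at the digits printed from compound 3 to compound 4 (within the scatter) and is the first reading of a change at this position, where the earlier steps replaced the whole group on the aromatic carbon. Measured against the other two groups on that carbon, 2-chloro-4-fluorobenzyl shows a 7.6-fold lower number from compound 2 to compound 4 (0.88 log units; beyond the scatter) and a 3.5-fold lower number from compound 1 to compound 4 (0.54 log units; beyond the scatter) and so stands where 3-(trifluoromethyl)benzyl stands. Nothing available offers a reason why these two substituted phenyl groups read alike.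

The compounds shown leave open whether an amine or a carboxylic acid on this phenyl ring would move the number beyond the scatter. They also do not say what a longer chain carrying 2-chloro-4-fluorophenyl would give.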